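From methyl to 1,1-difluoroethyl on compound 2

A few compounds are considered here, and "the series" means these few. Any claim that something is new, unique, unknown or untested is made for them only; others in the source may bear on it.

In an ADME assay on microsomes from liver (Canis lupus familiaris) for metabolic stability, read by LC-MS, using NADPH, with a stated time of 10 min, tested at 0.1 uM (on this read-out lower numbers stand for slow clearance and higher numbers for fast clearance), compound 2 (`Cc1cccc(N2C(=O)CSC2c2cccc(C(=O)NCCCCc3ccccc3)c2)c1`) gives 749 mL.min-1.g-1 as its measured clearance. Compound 1 (`COc1ccc(F)cc1N1C(=O)CSC1c1cccc(C(=O)NCCCCn2cccn2)c1`) gives 480 mL.min-1.g-1 and so lies within the scatter of compound 2. Compound 3 (`O=C(NCCCCc1ccccc1)c1cccc(C2SCC(=O)N2c2cccc(-c3c[nH]nn3)c2)c1`) gives 226 mL.min-1.g-1 and is clearly separated from compound 2.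

Compound 4 (`CC(F)(F)c1cccc(N2C(=O)CSC2c2cccc(C(=O)NCCCCc3ccccc3)c2)c1`) has not yet been measured. It differs from compound 2 in one place, and the change is 1,1-difluoroethyl in place of methyl on an aromatic carbon with 1,1-difluoroethyl in place of methyl on an aromatic carbon.

Within the data shown here, only one measured step replaces this methyl. Among the measured compounds shown here, that step is a 3.3-fold lower number from compound 2 to compound 3 (0.52 log units; beyond the scatter) and it brings in 1H-1,2,3-triazol-4-yl, a different group from the one in compound 4, so it is only a weak guide. For the measured compounds named here, compound 1 differs from compound 2 in more than one place and offers no single step. With so little to go on, no step beyond the scatter is expected in this assay and only a slight drop is anticipated. The estimated change is a 1.2-fold lower number from compound 2 to compound 4 (0.08 log units; within the scatter) and it would remain within the usual scatter. For compound 4 the expected value is 620 mL.min-1.g-1 with 300 mL.min-1.g-1 to 1150 mL.min-1.g-1 as the estimated range.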

Compound 4, intrinsic clearance in microsomes: 912 mL.min-1.g-1
Compound 4: middle estimate off by 1.5-fold (0.17 log units), on the low side, and the stated range covers the measured number.
By their numbers in this assay, from the lowest: compound 3; then compounds 1, 2 and 4 (each within the scatter of the next).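

In this assay, the only earlier replacement of this methyl was the 1H-1,2,3-triazol-4-yl group, and a 1.2-fold higher number from compound 2 to compound 4 (0.09 log units; within the scatter) now adds a second case: 1,1-difluoroethyl, with 4 heavy atoms in place of 1, leaves the clearance within the scatter of the methyl compound. Among these compounds, the same place on the ring, meta to a large group, does not respond alike to every group, since a 4.0-fold higher number from compound 3 to compound 4 (0.61 log units; beyond the scatter) separates the two replacements beyond the scatter and leaves compound 3 as the one compound of the three with a clearly different number. Nothing shown gives a measured reason for either step.

On these data alone, with only methyl, 1,1-difluoroethyl and 1H-1,2,3-triazol-4-yl at this place, it remains open whether the lower number of compound 3 is particular to that triazole ring or would also appear with another group here, such as a carboxylic acid, an amine or a different aromatic ring. As far as these compounds go, it is also open whether 1,1-difluoroethyl would give the same picture on a compound carrying another side chain, such as the pyrazole-bearing chain of compound 1.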